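A few compounds are considered here, and "the series" means these few. Any claim that something is new, unique, unknown or untested is made for them only; others in the source may bear on it.

The measured compounds are:
Compound 1, `O=C(NCCCN1CCN(c2ncccn2)CC1)NN(Cc1ccccc1)c1ccccc1`, which gives 18 nM in an assay on CHO cells for displacement of a labelled ligand from D(4) dopamine receptor (Homo sapiens), read by radioligand binding; a lower number here means a stronger inhibitor, a higher number a weaker inhibitor.
Compound 2, `O=C(NCCCN1CCN(c2ccc(Cl)cc2)CC1)NN(Cc1ccc(F)cc1)c1ccccc1`, which gives 17 nM in this assay.
Compound 3, `O=C(NCCCN1CCN(c2ccc(Br)cc2)CC1)NN(Cc1ccc(F)cc1)c1ccccc1`, which gives 46 nM in this assay.

Compound 3 stands at the highest number of the three, and its distance to both compound 1 and compound 2 is beyond the scatter. For the measured compounds named here, the only single-place step among the measured compounds is a 2.7-fold higher number from compound 2 to compound 3 (0.43 log units; beyond the scatter), a modest rise.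

Compound 4, `O=C(NCCCN1CCN(c2ncccn2)CC1)NN(Cc1ccc(F)cc1)c1ccccc1`, differs from compound 3 by pyrimidin-2-yl in place of 4-bromophenyl on an amine nitrogen in a ring. Going by the values given here, no measured step covers this exchange directly, so the step from compound 2 to compound 3 is only of indirect use: it shows that the group on this ring nitrogen shifts the number in this assay by a modest amount. Compound 1, which also carries pyrimidin-2-yl on that nitrogen, differs from compound 3 in two places and gives a number well below it. Compound 4 is therefore expected to return toward the numbers of compound 1 and compound 2, giving a lower number than compound 3 by a modest step, a 2.6-fold lower number from compound 3 to compound 4 (0.41 log units; beyond the scatter). The estimate for compound 4 in this assay is 18 nM, with a range from 7 nM to 45 nM.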

Compound 4, inhibition constant: 19 nM
The estimate for compound 4 lay 1.1-fold (0.02 log units) below the measured number; the measured number falls inside the stated range.
By their numbers in this assay, from the lowest: compounds 2, 1 and 4 (each within the scatter of the next); then compound 3.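

For the compounds shown here, on the amine nitrogen in the ring, pyrimidin-2-yl in place of 4-bromophenyl gives a 2.4-fold lower number from compound 3 to compound 4 (0.38 log units; beyond the scatter) in this assay, which is the first direct reading of this exchange and shows that a ring with hetero atoms can replace the carbon-only aromatic ring at this position without loss. Set against the chloro analogue, the same kind of exchange gives a 1.1-fold higher number from compound 2 to compound 4 (0.05 log units; within the scatter), so pyrimidin-2-yl and 4-chlorophenyl cannot be told apart at this position, and among the three groups seen on this nitrogen with the fluorinated benzyl group present, only 4-bromophenyl stands apart. Going by these compounds alone, the fluoro in place of hydrogen on an aromatic carbon, seen here alone for the first time, gives a 1.1-fold higher number from compound 1 to compound 4 (0.02 log units; within the scatter), so with pyrimidin-2-yl on the ring nitrogen this change leaves the number within the scatter.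

Nothing available bears on why the groups on this nitrogen fall as they do. From the compounds shown here alone, it remains open whether an unsubstituted phenyl, a pyridin-2-yl or a 4-methoxyphenyl on that nitrogen would sit with compound 2 and compound 4 or with compound 3, and what a longer chain would do in the core of compound 4.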